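The source may hold more compounds than are shown below. What is called first, only, known or untested is meant among the compounds shown, and "the series" means these compounds.

In an assay on HEK293 cells for agonist activity at transient receptor potential cation channel subfamily M member 8 (Homo sapiens), read by fluorescence and calcium flux, with a stated time of 15 min (on this read-out lower numbers stand for an effect already at smaller amounts and higher numbers for an effect only at larger amounts of compound), compound 1 `CCN(Cc1ccoc1)C(=O)COc1ccc(C)cc1` gives 136 nM, the second highest of the three numbers in hand. Compound 3 `CCN(Cc1cccs1)C(=O)COc1ccc2c(c1)COC2` gives 61 nM, a step beyond the scatter toward lower numbers, and compound 2 `Cc1ccc(OCC(=O)N(C)Cc2cccs2)cc1` gives 400 nM, the furthest of the three from compound 1 and also beyond the scatter. Within the data shown here, no two measured compounds differ in one place only, so no single change can be read off. Compound 4 `CCN(Cc1ccc(C)s1)C(=O)COc1ccc(C)cc1` is not yet measured. It differs from compound 1 as follows: 5-methylthiophen-2-yl in place of furan-3-yl on a saturated chain carbon bound to an amide-type nitrogen. With the other two compounds sitting on either side of compound 1, the step is expected to be small, if anything toward lower numbers, and is put at a 1.4-fold lower number from compound 1 to compound 4 (0.13 log units; within the scatter). Compound 4 is estimated at 100 nM, within 40 nM to 250 nM.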

Compound 4, half-maximal effective concentration: 178 nM
Estimate against measurement, compound 4: 1.8-fold (0.25 log units) below, within the range that was stated.
By their numbers in this assay, from the lowest: compound 3; then compounds 1 and 4 (each within the scatter of the next); then compound 2.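

In this assay, among these compounds, the change to 5-methylthiophen-2-yl from furan-3-yl on a saturated chain carbon bound to an amide-type nitrogen gives a 1.3-fold higher number from compound 1 to compound 4 (0.12 log units; within the scatter), the only one-place step in hand. At this place, the read-out does not separate these two five-membered aromatic rings. No measured finding bears on why.

Going by these compounds, the step changes ring and methyl together, so their separate contributions stay unknown. On these data alone, whether a ring-free group here, such as cyclohexyl or a longer alkyl chain carrying an amine, fits this range also stays open.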